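From compound 2 to compound 3: one ring exchanged

The compounds below may be only part of what the source reports. "The series", "measured", "known", "first", "only" and "open" are said of these compounds alone.

In a functional assay on MCF7 cells (Homo sapiens) for cytotoxicity, read by LDH release, with a stated time of 48 h (a higher number here means a weaker inhibitor, a lower number a stronger inhibitor), compound 2 (`Cn1cnc(C(=O)NNC(=O)COc2c(F)cc(C(=O)c3ccc(Cl)cc3)cc2Cl)c1`) gives 44400 nM. For the measured compounds named here, measured the same way, compound 1 (`O=C(COc1c(F)cc(C(=O)c2ccc(F)cc2)cc1Cl)NNC(=O)c1ccc(=O)oc1`) gives 61100 nM, and these two values lie within the usual scatter of each other, so compound 2 stands alongside the only other number available. Compound 3 (`O=C(COc1c(F)cc(C(=O)c2ccc(Cl)cc2)cc1Cl)NNC(=O)c1ccc(=O)oc1`) keeps the core of compound 2 and differs from it on a carbonyl carbon, with 1-methyl-1H-imidazol-4-yl leaving: a group of 7 heavy atoms (5 carbon, 2 oxygen; one six-membered aromatic ring with 1 hetero atom) in place of a group of 6 heavy atoms (4 carbon, 2 nitrogen; one five-membered aromatic ring with 2 hetero atoms), on a carbonyl carbon. Going by the values given here, no measured pair isolates this exchange. The entering group is also present in compound 1, which gives 61100 nM, so the evidence points to no clear shift in either direction. No change beyond the scatter is expected in this assay, and the estimated move is a 1.1-fold higher number from compound 2 to compound 3 (0.05 log units; within the scatter). For compound 3, the expected value is 50000 nM, with an estimated range from 23000 nM to 105000 nM.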

Compound 3, half-maximal inhibitory concentration: 83800 nM
The estimate for compound 3 lay 1.7-fold (0.22 log units) below the measured number; low and high end bracket the measured number.
By their numbers in this assay, from the lowest: compounds 2, 1 and 3 (each within the scatter of the next).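

For the compounds shown here, the exchange of 1-methyl-1H-imidazol-4-yl for the six-membered aromatic ring with one hetero atom, on a carbonyl carbon, amounts in this assay to a 1.9-fold higher number from compound 2 to compound 3 (0.28 log units; within the scatter), which gives the first direct reading of this exchange and shows no change beyond the scatter. With that ring held in place, chloro in place of fluoro on an aromatic carbon amounts to a 1.4-fold higher number from compound 1 to compound 3 (0.14 log units; within the scatter), so this single change also stays within the scatter. Nothing measured on these compounds accounts for either result.

From the compounds shown here alone, whether a longer alkyl chain or a phenyl ring carrying a carboxylic acid on this carbonyl carbon would move the number beyond the scatter remains open. So does the outcome of a bromo or methoxy group in place of the chloro on the aromatic carbon.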